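A methoxycarbonyl group takes the place of trifluoromethyl

The source may report more compounds than this note shows. Statements on the series, on what has been measured and on what is new or still open speak of the compounds shown alone.

Compound 1: `CCC(=O)N(c1ccc(Cl)cc1)C1CCCC1N(C)C`, > 50 mg/kg (a limit)
Compound 2: `CCC(=O)N(c1ccc(C(F)(F)F)cc1)C1CCCC1N(C)C`, 10 mg/kg
Compound 3: `CCC(=O)N(c1ccc(C(=O)OC)cc1)C1CCCC1N(C)C`, not yet measured

Within the data shown here, in a functional assay on the whole organism for positive allosteric modulation, with Mus musculus as the target (on this read-out higher numbers stand for an effect only at larger amounts of compound and lower numbers for an effect already at smaller amounts), compound 2 gives 10 mg/kg, the only actual number so far. Compound 1 gives > 50 mg/kg, and that value is a limit. Compound 3 differs from compound 2 by methoxycarbonyl in place of trifluoromethyl on an aromatic carbon, para to a large group. Among the measured compounds shown here, one measured step bears on this place, an at least 5.0-fold lower number from compound 1 to compound 2 (0.69 log units; beyond the scatter), with trifluoromethyl in place of chloro. It shows that this assay responds to the group here, but it involves no methoxycarbonyl, so it guides the direction only loosely. Losing trifluoromethyl is expected to give a moderately higher number. The expected step is a 2.5-fold higher number from compound 2 to compound 3 (0.40 log units; beyond the scatter). For compound 3 the estimate is 25 mg/kg, with an expected range of 8 mg/kg to 70 mg/kg.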

Compound 3, dose for half-maximal effect: > 50 mg/kg
Compound 3: no number, only a limit; the forecaster's own chance of this, stated with the estimate: 30%; middle value at least 2.0-fold (0.30 log units) from the limit.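

In this assay, methoxycarbonyl in place of trifluoromethyl on this aromatic carbon gives an at least 5.0-fold higher number from compound 2 to compound 3 (0.69 log units; beyond the scatter). This is a second replacement of trifluoromethyl at this place, and compound 2 is now the only one of the three compounds with an actual number, so among the groups shown only trifluoromethyl gives a readable dose here. Compound 1 and compound 3 each end in a limit, and the step between them cannot be read, which leaves chloro and methoxycarbonyl unordered: the limit of > 50 mg/kg in this assay, at which 2 of the 3 values shown sit.

On these data alone, the true size of the step to compound 3 stays open, as only its lower bound is known. Also open, as far as these compounds go, is whether any other group on this carbon, such as a nitrile, a methyl ketone or a carboxamide, would give an actual number in this assay.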